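A few compounds are considered here, and "the series" means these few. Any claim that something is new, unique, unknown or untested is made for them only; others in the source may bear on it.

Compound 2, with the structure `CCCC[C@H](OC(=O)CN(C)C)c1ccccc1C(=O)O[C@H]1CO[C@H]2[C@@H]1OC[C@H]2OC(=O)c1ccccc1[C@H](CCCC)OC(=O)CN(C)C`, was tested in a functional assay on cells (Platelet, Oryctolagus cuniculus) for inhibition, read by turbidimetry, with a stated time of 5 min (on this read-out higher numbers stand for weaker inhibition and lower numbers for stronger inhibition), and gives 310000 nM. Its companion, compound 1, with the structure `CCCC[C@H](OC(=O)CN1CCCC1)c1ccccc1C(=O)O[C@H]1CO[C@H]2[C@@H]1OC[C@H]2OC(=O)c1ccccc1[C@H](CCCC)OC(=O)CN1CCCC1`, gives 800000 nM in this assay, so compound 2 stands as the lower of the two numbers, a gap that goes beyond the usual scatter of repeated measurements.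

Compound 3, with the structure `CCCC[C@@H](OC(=O)CN(C)C)c1ccccc1C(=O)O[C@H]1CO[C@H]2[C@@H]1OC[C@H]2OC(=O)c1ccccc1[C@@H](CCCC)OC(=O)CN(C)C`, has not been measured. It differs from compound 2 only in this way: the two compounds have the same atoms and bonds and differ only in configuration as drawn: 2 of 6 stereo elements differ; a stereocentre at a saturated chain carbon is drawn S in compound 2 and R in compound 3; a stereocentre at a saturated chain carbon is drawn S in compound 2 and R in compound 3. Among the measured compounds shown here, no pair of measured compounds shows what such a change in configuration does here, so no measured step can guide the direction. The expectation is that the step from compound 2 to compound 3 in this assay, a 1.3-fold higher number from compound 2 to compound 3 (0.11 log units; within the scatter), stays close to none beyond the scatter, while allowing for a change in either direction.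

Compound 3 is therefore estimated to give 400000 nM in this assay, within a range from 100000 nM to 1600000 nM.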

Compound 3, half-maximal inhibitory concentration: 680000 nM
Compound 3: middle estimate off by 1.7-fold (0.23 log units), on the low side; the range from low to high includes it.
By their numbers in this assay, from the lowest: compound 2; then compounds 3 and 1 (each within the scatter of the next).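

Redrawing both stereocentres at the saturated chain carbons from S to R gives a 2.2-fold higher number from compound 2 to compound 3 (0.34 log units; beyond the scatter) in this assay and so shows that configuration at these carbons can shift this read-out, with the S,S form of this pair giving the stronger inhibition. Among the compounds shown here, the step is modest, yet it is the first measured sign in this set that the spatial arrangement at these carbons counts, and not only the groups attached. It can be traced to configuration alone, because of one plain fact: the fact that compounds 2 and 3 differ only in the configuration as drawn.

From the compounds shown here alone, both centres change together here, so what each one contributes on its own stays open. Also open, going by these compounds, is whether the same preference would hold with a longer chain at these carbons, or with a carboxylic acid in place of the dimethylamino group.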